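The source may hold more compounds than are shown below. What is called first, only, known or untested is meant among the compounds shown, and "the series" means these compounds.

For the measured compounds named here, compound 1 `CCCN(CC[C@H]1CC[C@H](NC(=O)/C=C/c2cccc(OC)c2)CC1)[C@H]1CCc2nc(N)sc2C1` gives 9.3 nM in an assay on brain for displacement of a labelled ligand from D(3) dopamine receptor (Rattus norvegicus) (a higher number here means a weaker inhibitor, a lower number a stronger inhibitor), the highest of the three numbers measured so far. Compound 2 `CCCN(CC[C@H]1CC[C@H](NC(=O)c2cccc3cnccc23)CC1)[C@H]1CCc2nc(N)sc2C1` gives 5.9 nM, and compound 3 `CCCN(CC[C@H]1CC[C@H](NC(=O)c2ccccc2-n2cccn2)CC1)[C@H]1CCc2nc(N)sc2C1` gives 2 nM. Compound 4 `CCCN(CC[C@H]1CC[C@H](NC(=O)c2cccc(-n3cncn3)c2)CC1)[C@H]1CCc2nc(N)sc2C1` carries 3-(1H-1,2,4-triazol-1-yl)phenyl in place of 2-(3-methoxyphenyl)ethenyl on a carbonyl carbon. Two measured steps replace the same 2-(3-methoxyphenyl)ethenyl group on that carbonyl carbon with an aromatic ring: a 1.6-fold lower number from compound 1 to compound 2 (0.20 log units; within the scatter), and a 4.7-fold lower number from compound 1 to compound 3 (0.67 log units; beyond the scatter). Both gave lower numbers, one within the scatter and one modestly beyond it, while the change from compound 2 to compound 3 shows a 3.0-fold lower number from compound 2 to compound 3 (0.47 log units; beyond the scatter). For compound 4, which also places an aromatic ring directly on the carbonyl, a modest lowering is expected, a step of a 2.3-fold lower number from compound 1 to compound 4 (0.37 log units; beyond the scatter). Compound 4 is therefore estimated at 4 nM, within a range from 1.5 nM to 12 nM.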

Compound 4, inhibition constant: 3 nM
Compound 4: the middle estimate sits 1.3-fold (0.12 log units) above what was measured; measured number inside the range.
By their numbers in this assay, from the lowest: compounds 3, 4, 2 and 1 (each within the scatter of the next, the first and the last beyond it).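

In this assay, placing 3-(1H-1,2,4-triazol-1-yl)phenyl on the carbonyl carbon instead of 2-(3-methoxyphenyl)ethenyl gives a 3.1-fold lower number from compound 1 to compound 4 (0.49 log units; beyond the scatter), so a second replacement carrying a five-membered aromatic ring also clears the scatter. The new group cannot be separated from the other two aromatic groups, with a 1.5-fold higher number from compound 3 to compound 4 (0.18 log units; within the scatter) and a 2.0-fold lower number from compound 2 to compound 4 (0.29 log units; within the scatter), both within the scatter. No evidence here explains these results. The compounds shown leave open how a plain phenyl group on that carbonyl carbon would compare, so the contribution of the triazole ring remains unknown.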